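A few compounds are considered here, and "the series" means these few. Any claim that something is new, unique, unknown or untested is made for them only; others in the source may bear on it.

Compound 1, `NC(=S)Nc1cccc(OCCCCCN2CCN(c3ccc(Cl)cc3)C2=O)c1`: 39000 nM
Compound 2, `NC(=S)Nc1cccc(OCCCCCN2CCN(c3ccc(Cl)c(Cl)c3)C2=O)c1`: 13000 nM
Compound 3, `NC(=S)Nc1cccc(OCCCCCN2CCN(c3ccc(Cl)cc3)C2=S)c1`: > 50000 nM (a limit of the test, not a number)

All three were tested in an ADME assay on Huh-7 cells (Homo sapiens) for cytotoxicity; on this read-out higher numbers stand for lower toxicity in this test and lower numbers for higher toxicity in this test. Compound 1 gives 39000 nM. Compound 2 gives 13000 nM. Compound 3 sits at the limit of > 50000 nM in this assay, at which 1 of the 3 values shown sits, so for compound 3 only a bound is known and not a number. Compound 4 is `NC(=S)Nc1cccc(OCCCCCN2CCN(c3ccc(Cl)c(Cl)c3)C2=S)c1`. It differs from compound 3 by chloro in place of hydrogen on an aromatic carbon. For the measured compounds named here, only one measured step bears on this change: a 3.0-fold lower number from compound 1 to compound 2 (0.48 log units; beyond the scatter), the same chloro added on the core of compound 1. That step was modest, yet beyond the scatter, and it lowered the number. If the change acts the same way on compound 3, compound 4 should come out with a lower number than the bound for compound 3, though because compound 3 stands at the limit of > 50000 nM in this assay, at which 1 of the 3 values shown sits, the starting point itself is uncertain, and a result that again falls at the limit cannot be ruled out. Compound 4 is expected to give about 28000 nM, likely between 10000 nM and 80000 nM. The step is expected to be an at least 1.7-fold lower number from compound 3 to compound 4 (0.25 log units; that floor lies within the scatter).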

Compound 4, half-maximal cytotoxic concentration: > 50000 nM
Compound 4 was reported as a limit; the forecaster's own chance of this, stated with the estimate: 40%; middle value at least 1.7-fold (0.25 log units) away from the limit.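

Compound 4 gives > 50000 nM in this assay, which is a limit of the test and not a number. Compound 3 also stands at a limit, so no step from compound 3 to compound 4 can be read: the limit of > 50000 nM in this assay, at which 2 of the 4 values shown sit.

The compounds shown leave open whether going from 4-chlorophenyl to 3,4-dichlorophenyl lowers the number on the core of compound 3, as it did on the core of compound 1.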